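Swapping the Sulfonamide Headgroup on a Chlorinated Core

This account rests on a few compounds, and the source may have more. Where it says the series, first, only, none or still open, it means among the compounds named here.

Of the compounds shown here, three have been measured in a functional assay on A549 cells (Homo sapiens) for cytotoxicity, read by sulforhodamine B assay, with a stated time of 72 h; a higher number here means a weaker inhibitor, a lower number a stronger inhibitor. Compound 3 `O=C1/C(=C/c2coc3ccccc3c2=O)N=C(c2ccc(Cl)cc2)N1c1ccc(S(=O)(=O)Nc2ccccn2)cc1` gives only a limit of the assay, > 100000 nM. Compound 2 `Cc1cc(NS(=O)(=O)c2ccc(N3C(=O)/C(=C/c4coc5ccccc5c4=O)N=C3c3ccc(Cl)cc3)cc2)no1` likewise gives only a limit, > 100000 nM. Compound 1 `Cc1cc(C)nc(NS(=O)(=O)c2ccc(N3C(=O)/C(=C/c4coc5ccccc5c4=O)N=C3c3ccccc3)cc2)n1`, which carries the 4,6-dimethylpyrimidin-2-yl group on its sulfonamide nitrogen, gives 63200 nM in this assay. Going by the values given here, the one directly comparable step, a step that the two limits leave unreadable from compound 2 to compound 3, cannot be sized because of the limit of > 100000 nM in this assay, at which 2 of the 3 values shown sit. Compound 4 `Cc1cc(C)nc(NS(=O)(=O)c2ccc(N3C(=O)/C(=C/c4coc5ccccc5c4=O)N=C3c3ccc(Cl)cc3)cc2)n1` differs from compound 3 by 4,6-dimethylpyrimidin-2-yl in place of pyridin-2-yl on a sulfonamide nitrogen. Since compound 1 with the same sulfonamide group reached 63200 nM, compound 4 is expected to give a measurable but weak value, an estimated step of an at least 1.2-fold lower number from compound 3 to compound 4 (0.09 log units; that floor lies within the scatter). The estimate for compound 4 is 80000 nM, within 30000 nM to 200000 nM.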

Compound 4, half-maximal inhibitory concentration: 52600 nM
Beside the measured number, compound 4's estimate is 1.5-fold (0.18 log units) above it; the range from low to high includes it.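

With the chloro group on the core, 4,6-dimethylpyrimidin-2-yl on a sulfonamide nitrogen gives a readable number, whereas compound 2 and compound 3 each gave only a limit of the assay (an at least 1.9-fold lower number from compound 3 to compound 4 (0.27 log units; that floor lies within the scatter); an at least 1.9-fold lower number from compound 2 to compound 4 (0.27 log units; that floor lies within the scatter)). From the compounds shown here alone, both steps are only floors, so their true size stays unknown. Chloro in place of hydrogen on an aromatic carbon makes no difference beyond the scatter (a 1.2-fold lower number from compound 1 to compound 4 (0.08 log units; within the scatter)).

The compounds shown leave open whether a butyl chain or a ring carrying an amine on that sulfonamide nitrogen would move the number further.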